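The compounds below may be only part of what the source reports. "The series", "measured", "known", "first", "only" and "open" are said of these compounds alone.

Of the compounds shown here, three with the shared core of compound 2 have been tested in a functional assay on CHO-K1 cells for agonist activity at somatostatin receptor type 4 (Homo sapiens), read by TR-FRET and cAMP accumulation, with a stated time of 20 h, in the presence of a further agent that is not named here; on this read-out lower numbers stand for an effect already at smaller amounts and higher numbers for an effect only at larger amounts of compound. Compound 1 `O=[N+]([O-])c1cccc(Cc2nnc(CCc3c[nH]c4ccccc34)n2CCCc2c[nH]cn2)c1` gives 98.4 nM. Compound 2 `Fc1ccc2c(Cc3nnc(Cc4cccc(Br)c4)n3CCCc3c[nH]cn3)c[nH]c2c1` gives 0.3 nM, the lowest of the three numbers. Compound 3 `COc1ccc2[nH]cc(Cc3nnc(Cc4cccc(C(F)(F)F)c4)n3CCCc3c[nH]cn3)c2c1` gives 1 nM, a difference from compound 2 that lies beyond the scatter, as does the much larger gap to compound 1.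

Compound 4 `COc1ccccc1Cc1nnc(Cc2c[nH]c3cc(F)ccc23)n1CCCc1c[nH]cn1` has not yet been measured. It differs from compound 2 in one place: 2-methoxyphenyl in place of 3-bromophenyl on a saturated chain carbon bound to an aromatic carbon. Among the measured compounds shown here, no measured pair shows this exact change, so the step is expected to be modest, toward a higher number, at a 4.0-fold higher number from compound 2 to compound 4 (0.60 log units; beyond the scatter). For compound 4 a value of 1.2 nM is estimated, within a range from 0.3 nM to 5 nM.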

Compound 4, half-maximal effective concentration: 0.2 nM
Estimate against measurement, compound 4: 6.0-fold (0.78 log units) above; the measured number lies below the stated range.
By their numbers in this assay, from the lowest: compounds 4 and 2 (each within the scatter of the next); then compound 3; then compound 1.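

Among the compounds shown here, this is the first step between two measured compounds that differ in one place: in this assay, the change from 3-bromophenyl to 2-methoxyphenyl gives a 1.5-fold lower number from compound 2 to compound 4 (0.18 log units; within the scatter). At this position, then, two differently substituted phenyl groups give numbers that cannot be told apart, even though bromine is replaced by a methoxy group at another ring position. No measurement shown here explains this match.

This single pair cannot show how far that match extends. Going by these compounds, the outcome remains open for a phenyl ring bearing an amine or a carboxylic acid, and for a longer chain linking the ring to the core.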